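The source may hold more compounds than are shown below. What is called first, only, known or untested is meant among the compounds shown, and "the series" means these compounds.

Working notes on a small series sharing one core, assessed in a functional assay on Vero cells (Chlorocebus sabaeus) for cytotoxicity, read by MTT assay; a higher number here means that more compound is tolerated, a lower number that less compound is tolerated. Compound 1 `Nc1cn(COCCO)c(=O)[nH]c1=O` gives > 497000 nM, which is a limit of the assay. Compound 3 `O=c1[nH]c(=O)n(COCCO)cc1C(F)(F)F` gives > 393000 nM, likewise a limit. The step from compound 1 to compound 3 is a step that the two limits leave unreadable from compound 1 to compound 3. Compound 2 `CCc1cn(COCCO)c(=S)[nH]c1=O` gives > 478000 nM, again a limit. Compound 2 thus stands at a limit, as do the two other values shown, and no order among the three can be read. Compound 4 `CCOC(=O)c1cn(COCCO)c(=S)[nH]c1=O` differs from compound 2 by ethoxycarbonyl in place of ethyl on an aromatic carbon. Going by the values given here, no measured step bears on this change; the single step available is unreadable. Compound 4 is expected near the same limit, estimated at 450000 nM (range 150000 nM to 1500000 nM). Compound 4 is expected to show a step of an at least 1.0-fold lower number from compound 2 to compound 4 (0.02 log units; that floor lies within the scatter).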

Compound 4, half-maximal cytotoxic concentration: > 364000 nM
Compound 4 gave a limit, no number (the forecaster's own chance of this, stated with the estimate: 75%); the middle value does not contradict the limit.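

Compound 2 and compound 4 both stand at limits, so the step between them, ethoxycarbonyl in place of ethyl, cannot be read. The compounds shown leave open whether any member of the series gives an actual number in this assay.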